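A few compounds are considered here, and "the series" means these few. Any claim that something is new, unique, unknown or untested is made for them only; others in the source may bear on it.

Measured so far:
- compound 1 `COC(=O)c1cc(C)ccc1OC(=O)COc1cc(O)c2c(=O)cc(-c3ccccc3)oc2c1`: 306000 nM
- compound 2 `COC(=O)c1ccccc1OC(=O)COc1cc(O)c2c(=O)cc(-c3ccccc3)oc2c1`: 265000 nM

Both numbers come from an ADME assay on cells (T-cell, Mus musculus, strain BALB/c) for cytotoxicity, read by MTT assay, with a stated time of 48 h; a lower number here means that less compound is tolerated, a higher number that more compound is tolerated. On the two numbers shown, compound 2 stands together with compound 1: the only change between them, hydrogen in place of methyl on an aromatic carbon, gives a 1.2-fold lower number from compound 1 to compound 2 (0.06 log units; within the scatter), so the two cannot be told apart on this assay.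

The next compound, compound 3 `COC(=O)c1ccc(Br)cc1OC(=O)COc1cc(O)c2c(=O)cc(-c3ccccc3)oc2c1`, is made from compound 2 by one change: bromo in place of hydrogen on an aromatic carbon

Within the data shown here, only one measured step exists to compare with, the one from compound 1 to compound 2, and it swapped a small group for hydrogen at a different place with no change beyond the scatter. Among the measured compounds shown here, no measured step shows what a bromo group does on this ring, so the expectation rests on the one small step seen so far and on compound 2 itself. Compound 3 is therefore expected to give about 250000 nM in this assay, with a likely range from 100000 nM to 550000 nM, which means an expected step of a 1.1-fold lower number from compound 2 to compound 3 (0.03 log units; within the scatter), within the scatter.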

Compound 3, half-maximal cytotoxic concentration: 326000 nM
Compound 3: the middle estimate sits 1.3-fold (0.12 log units) below what was measured, within the range that was stated.
By their numbers in this assay, from the lowest: compounds 2, 1 and 3 (each within the scatter of the next).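

In this assay, placing bromo on this aromatic carbon, para to the methoxycarbonyl group, gives a 1.2-fold higher number from compound 2 to compound 3 (0.09 log units; within the scatter), so on this evidence a bromine atom at this position leaves the compound indistinguishable from its parent carrying hydrogen. Compound 1, with methyl elsewhere on the same ring, compares in the same way, with a 1.1-fold higher number from compound 1 to compound 3 (0.03 log units; within the scatter), so the three compounds cannot be told apart and neither ring change shown here moves the number beyond the usual scatter. Nothing measured alongside these numbers bears on what lies behind them.

Still open, going by these compounds, is whether a group of a different kind on this same carbon, such as an amine or a hydroxyl group, would give a number that could be separated from those of compound 2 and compound 3. The compounds shown also leave open what would follow if the methoxycarbonyl group were replaced by a carboxylic acid, or if the ester link to the shared core were replaced by an amide.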